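A pyrrolidin-1-yl swap on compound 3

The compounds below may be only part of what the source reports. "The series", "measured", "known", "first", "only" and "open" are said of these compounds alone.

Compound 1 `CCCCCCC[C@@H](C/C=C/CCC(=O)N1CCCCC1)OC`: > 100000 nM (a limit)
Compound 2 `CCCCCCC[C@H](O)C/C=C/CCC(=O)NCC(C)C`: > 100000 nM (a limit)
Compound 3 `CCCCCCC[C@H](O)C/C=C/CCC(=O)N1CCCCC1`: > 100000 nM (a limit)

These results come from a functional assay on SW-620 cells (Homo sapiens) for inhibition, read by trypan blue exclusion, with a stated time of 48 h (a higher number here means a weaker inhibitor, a lower number a stronger inhibitor), and each one is a limit of the assay, not a number. Compound 3 stands at > 100000 nM as such a limit. It has no company among measured numbers, as the record so far is the limit of > 100000 nM in this assay, at which 3 of the 3 values shown sit, and nothing in the series has yet given a readable potency.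

Compound 4 `CCCCCCC[C@H](O)C/C=C/CCC(=O)N1CCCC1` carries pyrrolidin-1-yl in place of piperidin-1-yl on a carbonyl carbon. The closest measured change sits at that same place, where isobutylamino gives way to piperidin-1-yl: a step that the two limits leave unreadable from compound 2 to compound 3. The other change lies elsewhere, with hydrogen in place of methyl on an oxygen on a saturated carbon: a step that the two limits leave unreadable from compound 1 to compound 3. Neither has a size that can be read, so neither suggests a direction. The expected outcome is no step beyond the usual scatter, and the estimated change is a number no higher from compound 3 to compound 4 (the limit leaves the size open). Most likely the assay will again report only a limit. For compound 4 the estimate is 100000 nM with an expected range from 40000 nM to 250000 nM in this assay.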

Compound 4, half-maximal inhibitory concentration: > 100000 nM
Compound 4: no number, only a limit (the forecaster's own chance of this, stated with the estimate: 80%); the middle value lies on the limit itself.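

In this assay compound 4 gives > 100000 nM, which is a limit and not a number. Among these compounds, no step from compound 2 or compound 3 to compound 4 can be read, as both of those compounds also sit at a limit. The compounds shown leave open whether pyrrolidin-1-yl, piperidin-1-yl and isobutylamino on a carbonyl carbon differ at all in potency: the limit of > 100000 nM in this assay, at which 4 of the 4 values shown sit.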